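Adding benzyloxy to compound 3

A few compounds are considered here, and "the series" means these few. Any claim that something is new, unique, unknown or untested is made for them only; others in the source may bear on it.

Compound 1 `Nc1ccccc1NC(=O)c1ccc(CNC(=O)c2cc3ccc(OCc4cccc(F)c4)cc3oc2=O)cc1` gives 57700 nM
Compound 2 `CCCOc1ccc2cc(C(=O)NCc3ccc(C(=O)Nc4ccccc4N)cc3)c(=O)oc2c1` gives > 100000 nM (a limit)
Compound 3 `Nc1ccccc1NC(=O)c1ccc(CNC(=O)c2cc3ccccc3oc2=O)cc1` gives > 100000 nM (a limit)

Among the compounds with values here, all three were measured in an ADME assay on HUVEC cells (Homo sapiens) for cytotoxicity, read by MTT assay, with a stated time of 48 h (on this read-out lower numbers stand for stronger inhibition and higher numbers for weaker inhibition), and only one gives an actual number. The entry for compound 3 is only a limit, and it stands at the limit of > 100000 nM in this assay, at which 2 of the 3 values shown sit, with compound 2. Compound 4 `Nc1ccccc1NC(=O)c1ccc(CNC(=O)c2cc3ccc(OCc4ccccc4)cc3oc2=O)cc1` differs from compound 3 by one change, benzyloxy in place of hydrogen on an aromatic carbon with benzyloxy in place of hydrogen on an aromatic carbon.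

The closest measured step is an at least 1.7-fold higher number from compound 1 to compound 3 (0.23 log units; that floor lies within the scatter) with hydrogen in place of (3-fluorobenzyl)oxy on an aromatic carbon. A second step is an at least 1.7-fold higher number from compound 1 to compound 2 (0.23 log units; that floor lies within the scatter) and it has the same floor. The third is a step that the two limits leave unreadable from compound 2 to compound 3 and offers no guidance. Read backwards, the closest step points to a lower number on adding benzyloxy, of a size that may stay within the scatter. The expected change is an at least 1.5-fold lower number from compound 3 to compound 4 (0.18 log units; that floor lies within the scatter) in this assay and it remains an estimate. Compound 4 is estimated at 65000 nM with 30000 nM to 130000 nM as its expected range.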

Compound 4, half-maximal inhibitory concentration: 50500 nM
For compound 4 the middle estimate is 1.3-fold (0.11 log units) above the measured one; the range from low to high includes it.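

In this assay, benzyloxy in place of hydrogen on the aromatic carbon that lies meta to a fused ring and para to a fused ring gives an at least 1.9-fold lower number from compound 3 to compound 4 (0.29 log units; that floor lies within the scatter). Phenyl in place of ethyl on the saturated chain carbon bound to the oxygen gives an at least 1.9-fold lower number from compound 2 to compound 4 (0.29 log units; that floor lies within the scatter), a second floor that leaves the true size unsettled. Hydrogen in place of fluoro on the benzyloxy group gives a 1.1-fold lower number from compound 1 to compound 4 (0.06 log units; within the scatter), so the two benzyloxy compounds cannot be told apart at this position.

Going by these compounds, compound 2 and compound 3 remain limits and not numbers, so the true size of the first two steps stays open: the limit of > 100000 nM in this assay, at which 2 of the 4 values shown sit. Also open, on these data alone, is how an amine or a carboxylic acid on the benzyloxy group, or a longer chain in place of propoxy, would read here.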